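Swapping the benzylidene ring on an adenosine hydrazone

The compounds below may be only part of what the source reports. "The series", "measured", "known", "first", "only" and "open" are said of these compounds alone.

Three hydrazone derivatives sharing one nucleoside core were tested in an assay on CHO-K1 cells for displacement of a labelled ligand from adenosine receptor A1 (Homo sapiens), read by scintillation counting, with a stated time of 60 min; a higher number here means a weaker inhibitor, a lower number a stronger inhibitor. Compound 1, `Nc1nc(N/N=C/c2ccc(OCc3ccc(F)cc3)cc2)nc2c1ncn2[C@@H]1O[C@H](CO)[C@@H](O)[C@H]1O`, gives 70 nM. Compound 2, `CCOc1cc(/C=N/Nc2nc(N)c3ncn([C@@H]4O[C@H](CO)[C@@H](O)[C@H]4O)c3n2)ccc1O`, gives 6940 nM, which is the higher of the two numbers reported, far above compound 1 and beyond the usual scatter. For compound 3, `Nc1nc(N/N=C/c2ccc(OCc3ccccc3)c(OCc3ccccc3)c2)nc2c1ncn2[C@@H]1O[C@H](CO)[C@@H](O)[C@H]1O`, this assay reports only a limit, > 10000 nM; that limit is described as the limit of > 10000 nM in this assay, at which 1 of the 3 values shown sits.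

The next compound, compound 4, `N#Cc1ccccc1/C=N/Nc1nc(N)c2ncn([C@@H]3O[C@H](CO)[C@@H](O)[C@H]3O)c2n1`, has not yet been measured. It differs from compound 2 in one place: 2-cyanophenyl in place of 3-ethoxy-4-hydroxyphenyl on a carbon with a double bond to nitrogen. Going by the values given here, no measured pair shows this exact exchange, so the direction of the step is uncertain. The expectation is a moderate improvement, with compound 4 expected to fall between the weak compound 2 and the strong compound 1, giving an estimated step of a 3.5-fold lower number from compound 2 to compound 4 (0.54 log units; beyond the scatter). On that basis compound 4 is estimated at 2000 nM, expected to lie between 300 nM and 10000 nM.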

Compound 4, inhibition constant: 2.9 nM
Compound 4: middle estimate off by 690-fold (2.84 log units), on the high side; the whole stated range lies above it.
By their numbers in this assay, from the lowest: compound 4; then compound 1; then compound 2. At a limit, above all of these: compound 3.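

The exchange of 3-ethoxy-4-hydroxyphenyl for 2-cyanophenyl is the first change at a single place among these compounds, and in this assay it gives a 2400-fold lower number from compound 2 to compound 4 (3.38 log units; beyond the scatter) as its step. Going by these compounds alone, the group on this carbon can therefore shift the number a long way while the rest of the molecule stays the same, something the earlier compounds could not show, as no two of them formed such a single-place pair. Nothing measured here explains why the step is so large.

Going by these compounds, the exchange removes the ethoxy and hydroxyl groups and brings in the nitrile all at once, so what each part contributes remains open. A plain phenyl ring, or an amine or a carboxylic acid in place of the nitrile, would help separate those contributions.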